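The source may hold more compounds than are shown below. What is called first, only, known or untested is meant among the compounds shown, and "the series" means these compounds.

Measured compounds, each in a physicochemical assay for solubility, using the shake flask method, in simulated intestinal fluid, measured as kinetic solubility, with a stated time of 2 h, at 25 degrees C, at pH 6.5; on this read-out lower numbers stand for lower solubility and higher numbers for higher solubility:
Compound 1 `Cc1nnc(-c2nc(C)c3c(c2N)C(=O)N(Cc2ccccc2)C3=O)o1` gives < 5000 nM, a limit of the assay.
Compound 2 `Cc1nc(-c2nc(C(F)(F)F)no2)c(N)c2c1C(=O)N(Cc1ccccc1)C2=O` gives < 5000 nM, a limit of the assay.
Compound 3 `Cc1noc(-c2nc(C)c3c(c2N)C(=O)N(Cc2ccc(Cl)cc2)C3=O)n1` gives < 5000 nM, a limit of the assay.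

Compound 3 thus stands at the limit, where the other two compounds also sit (the limit of < 5000 nM in this assay, at which 3 of the 3 values shown sit). Among the compounds with values here, the single step between measured compounds differing in one place, a step that the two limits leave unreadable from compound 1 to compound 2, cannot be read from its two limits, so no measured step bears on the move to compound 4 `COc1ccccc1CN1C(=O)c2c(C)nc(-c3nc(C)no3)c(N)c2C1=O`. That move is 2-methoxyphenyl in place of 4-chlorophenyl on a saturated chain carbon bound to an amide-type nitrogen in a ring. With every value a limit, neither direction nor size of this change is readable, and compound 4 is expected to remain near the same limit, the estimated step being a step that the limit leaves unreadable from compound 3 to compound 4. Compound 4 is estimated at 3000 nM, within 500 nM to 8000 nM.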

Compound 4, solubility: < 5000 nM
Compound 4: only a limit was reported; the forecaster's own chance of this, stated with the estimate: 70%; the middle value lies beyond the limit too.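

Compound 3 and compound 4 both give only limits, so no new step can be read between them: the limit of < 5000 nM in this assay, at which 4 of the 4 values shown sit.

The compounds shown leave open the actual solubility of each compound and whether 2-methoxybenzyl in place of 4-chlorobenzyl changes it in either direction.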